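Removing tert-butoxycarbonyl from compound 2

A few compounds are considered here, and "the series" means these few. Any claim that something is new, unique, unknown or untested is made for them only; others in the source may bear on it.

Compound 1 `O=C(NNC(=O)c1ccc([N+](=O)[O-])o1)c1ccc2ccccc2c1` gives 2000 nM
Compound 2 `CC(C)(C)OC(=O)Nc1ccc2cc(C(=O)NNC(=O)c3ccc([N+](=O)[O-])o3)ccc2c1` gives 2000 nM

Among the compounds with values here, in a functional assay on MRC5 cells (Homo sapiens) for cytotoxicity (on this read-out lower numbers stand for higher toxicity in this test and higher numbers for lower toxicity in this test), compound 2 reads 2000 nM, level with compound 1 at the digits given, its only measured neighbour. Compound 3 `Nc1ccc2cc(C(=O)NNC(=O)c3ccc([N+](=O)[O-])o3)ccc2c1` differs from compound 2 in one place: hydrogen in place of tert-butoxycarbonyl on a nitrogen on an aromatic ring. In words, this is hydrogen in place of tert-butoxycarbonyl on a nitrogen on an aromatic ring, so that (tert-butoxycarbonyl)amino becomes amino.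

Within the data shown here, only one measured step bears on this change: no change at the digits printed from compound 1 to compound 2 (within the scatter), with (tert-butoxycarbonyl)amino in place of hydrogen on an aromatic carbon. That step lies within the scatter, so adding the whole group left this assay unmoved. Among the measured compounds shown here, it is only indirect evidence, however, since no measured compound carries the amino group itself. The expectation therefore rests on that single flat step and points in no particular direction, with no change beyond the scatter the likeliest outcome. The expected size is no change at the digits printed from compound 2 to compound 3 (within the scatter). Compound 3 is estimated at 2000 nM, with an expected range of 800 nM to 5000 nM.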

Compound 3, half-maximal cytotoxic concentration: 770 nM
Compound 3: the middle estimate sits 2.6-fold (0.41 log units) above what was measured; the measured number lies below the stated range.
By their numbers in this assay, from the lowest: compound 3; then compounds 1 and 2 (each within the scatter of the next).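

In this assay the free amino group separates itself from the other two compounds, with a 2.6-fold lower number from compound 2 to compound 3 (0.41 log units; beyond the scatter) and with a 2.6-fold lower number from compound 1 to compound 3 (0.41 log units; beyond the scatter) as well. The earlier pair gave no sign of this, since no change at the digits printed from compound 1 to compound 2 (within the scatter) suggested a place on the core where substitution made no difference; that flat step now holds only for (tert-butoxycarbonyl)amino and cannot stand for this position as a whole. Removing the tert-butoxycarbonyl group and adding amino to the core of compound 1 thus arrive at the same result, a modest move towards a lower number, and nothing measured here accounts for it.

As far as these compounds go, whether the shift belongs to the amino group specifically or would appear with other small groups in this place remains open: a methylamino or dimethylamino group, an acetylamino group or a hydroxyl group would each test that. From the compounds shown here alone, it also remains open whether amino would give a similar step at another place on the core, and how the nitrofuran-free part of the shared core contributes cannot be read from these three compounds.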